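From Amino to Bromo on a Shared Core

The source may hold more compounds than are shown below. What is called first, only, known or untested is meant among the compounds shown, and "the series" means these compounds.

Of the compounds shown here, three have numbers so far in a functional assay on CEM-SS cells (Homo sapiens) for cytotoxicity; a lower number here means a stronger inhibitor, a higher number a weaker inhibitor. Compound 1 `Cc1cccc(Cn2c(N)nc3cc(Cl)c(Cl)cc32)c1` gives 48000 nM, and compound 2 `Nc1nc2cc(Cl)c(Cl)cc2n1Cc1ccccc1Cl` gives 36000 nM. These two values lie within the usual scatter of each other, so compound 2 cannot be ranked against compound 1. Compound 3 `Clc1ccc(Cn2c(Br)nc3cc(Cl)c(Cl)cc32)cc1` gives only a limit, > 100000 nM, and not a true number.

Compound 4 `Clc1cc2nc(Br)n(Cc3ccccc3Cl)c2cc1Cl` has not yet been measured. It keeps everything in compound 2 except for one group: bromo in place of amino on an aromatic carbon. That carbon sits between two ring nitrogen atoms, on a five-membered aromatic ring that is part of a fused system.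

Among the compounds with values here, no measured pair shows this single change on its own. Compound 3 also carries bromo and reaches the limit of > 100000 nM, so a modest step to a higher number, meaning a weaker inhibitor, is expected in this assay. In numbers, the expected change is a 2.5-fold higher number from compound 2 to compound 4 (0.40 log units; beyond the scatter). Compound 4 is estimated at 90000 nM, with an expected range from 35000 nM to 200000 nM.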

Compound 4, half-maximal inhibitory concentration: 74000 nM
Estimate against measurement, compound 4: 1.2-fold (0.09 log units) above, within the range that was stated.
By their numbers in this assay, from the lowest: compounds 2, 1 and 4 (each within the scatter of the next, the first and the last beyond it). At a limit, above all of these: compound 3.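

Read on its own for the first time, bromo in place of amino on an aromatic carbon gives, in this assay, a 2.1-fold higher number from compound 2 to compound 4 (0.31 log units; beyond the scatter). The step is modest, but it lies beyond the scatter, so this carbon between two ring nitrogen atoms is a place where the choice of group can be seen in the read-out, and here the change leads to a weaker inhibitor. Compound 4 has a true number, so bromo on this carbon does not by itself bring a compound to the limit where compound 3 stands: the limit of > 100000 nM in this assay, at which 1 of the 4 values shown sits.

With only amino and bromo shown on this carbon, the data cannot tell how much of the step comes from losing amino and how much from gaining bromo, and a methoxy group or a nitrile in the same place would help to separate the two. Within the data shown here, it also remains open whether the same change gives a step of similar size when the group on the neighbouring ring nitrogen is the one in compound 1.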